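A few compounds are considered here, and "the series" means these few. Any claim that something is new, unique, unknown or untested is made for them only; others in the source may bear on it.

Measured so far in a functional assay on EBC-1 cells (Homo sapiens) for antiproliferative activity, read by sulforhodamine B assay, with a stated time of 72 h; a lower number here means a stronger inhibitor, a higher number a weaker inhibitor:
compound 1 `Cn1cc(-c2ccc(=O)n(CCOc3ccnc4cc(OCCCC(=O)NO)ccc34)n2)cn1`: 870 nM
compound 2 `Cn1cc(-c2ccc(=O)n(CCOc3ccnc4cc(OCCCCC(=O)NO)ccc34)n2)cn1`: 370 nM
compound 3 `Cn1cc(-c2ccc(=O)n(CCOc3ccnc4cc(OCCCCCCC(=O)NO)ccc34)n2)cn1`: 210 nM

Compound 1 stands highest of the three numbers in this assay. The two steps away from it are a 2.4-fold lower number from compound 1 to compound 2 (0.37 log units; beyond the scatter) and a 4.1-fold lower number from compound 1 to compound 3 (0.62 log units; beyond the scatter), both modest. Compound 4 `CNC(=O)CCCCCOc1ccc2c(OCCn3nc(-c4cnn(C)c4)ccc3=O)ccnc2c1` differs from compound 1 by 2-(methylcarbamoyl)ethyl in place of hydroxycarbamoyl on a saturated chain carbon, three bonds along the chain from an oxygen on an aromatic ring. Both measured steps only lengthen the chain while keeping hydroxycarbamoyl at its end, so they bear on the added chain length and point to a modest gain at most. For the measured compounds named here, no measured step covers the swap of hydroxycarbamoyl for methylcarbamoyl, so that part has no precedent here. Compound 4 is therefore expected near 700 nM, within 200 nM to 3000 nM. The expected step is a 1.2-fold lower number from compound 1 to compound 4 (0.09 log units; within the scatter), which may be no change beyond the scatter.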

Compound 4, half-maximal inhibitory concentration: 79 nM
Compound 4: middle estimate off by 8.9-fold (0.95 log units), on the high side; measured number below the stated range.
By their numbers in this assay, from the lowest: compound 4; then compounds 3 and 2 (each within the scatter of the next); then compound 1.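

Compound 4 carries methylcarbamoyl at its chain end instead of hydroxycarbamoyl, yet in this assay it has the lowest number of the set: an 11-fold lower number from compound 1 to compound 4 (1.04 log units; beyond the scatter), with a 4.7-fold lower number from compound 2 to compound 4 (0.67 log units; beyond the scatter) and a 2.7-fold lower number from compound 3 to compound 4 (0.42 log units; beyond the scatter). In these cells, then, a hydroxycarbamoyl end is not needed for antiproliferative activity. No measurement shown here accounts for this gain.

The end group and the chain length change together in every step to compound 4, so their contributions cannot be separated. Going by these compounds, how a carboxylic acid at the same chain end would compare also remains open.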